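Replacing a benzyl-bearing tetrazole with a methyl group

The source may hold more compounds than are shown below. What is called first, only, known or untested is meant among the compounds shown, and "the series" means these compounds.

Of the compounds shown here, three sharing one core have been measured in a functional assay (Pituitary gland cell) with Rattus norvegicus as the target; a higher number here means that more compound is needed for the effect, a lower number that less compound is needed. Compound 1 `CC(C)(N)CC(=O)N[C@@H]1CCc2ccccc2N(Cc2ccc(-c3ccccc3-c3nnn(Cc4ccccc4)n3)cc2)C1=O` carries a 2-benzyl-2H-tetrazol-5-yl group on an outer ring, and in this assay compound 1 gives 1 uM. Compound 2 `CC(C)(N)CC(=O)N[C@@H]1CCc2ccccc2N(Cc2ccc(-c3ccccc3S(=O)(=O)NC(C)(C)C)cc2)C1=O` bears a (tert-butyl)sulfamoyl group in the same place; in this assay compound 2 gives 4 uM. Compound 3 `CC(C)(N)CC(=O)N[C@@H]1CCc2ccccc2N(Cc2ccc(-c3ccccc3-c3nnnn3Cc3ccccc3)cc2)C1=O` carries a 1-benzyl-1H-tetrazol-5-yl group, and in this assay compound 3 gives 0.7 uM, the lowest of the three numbers, although its difference from compound 1 is within the scatter (a 1.4-fold lower number from compound 1 to compound 3 (0.15 log units; within the scatter)), while the gap to compound 2 is beyond it (a 5.7-fold lower number from compound 2 to compound 3 (0.76 log units; beyond the scatter)).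

Compound 4 `Cc1ccccc1-c1ccc(CN2C(=O)[C@H](NC(=O)CC(C)(C)N)CCc3ccccc32)cc1` is not yet measured. It differs from compound 3 in one place: methyl in place of 1-benzyl-1H-tetrazol-5-yl on an aromatic carbon, the entering group sitting on an aromatic carbon of a six-membered aromatic ring of carbon only, ortho to a large group. Among the measured compounds shown here, the steps that bear on this are those in which a benzyl-bearing tetrazole was exchanged for a smaller group: a 4.0-fold higher number from compound 1 to compound 2 (0.60 log units; beyond the scatter) and a 5.7-fold lower number from compound 2 to compound 3 (0.76 log units; beyond the scatter). In both, the smaller group came with a modestly higher number. A methyl is smaller still, so a larger rise is expected, with wide uncertainty because nothing so small has been measured here. The step from compound 3 to compound 4 is expected to be an 8.6-fold higher number from compound 3 to compound 4 (0.93 log units; beyond the scatter). Compound 4 is estimated at 6 uM, in a range from 1.5 uM to 30 uM.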

Compound 4, concentration for half-maximal effect: 1 uM
Compound 4: middle estimate off by 6.0-fold (0.78 log units), on the high side, and the stated range ends above it.
By their numbers in this assay, from the lowest: compounds 3, 1 and 4 (each within the scatter of the next); then compound 2.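

On an aromatic carbon of a six-membered aromatic ring of carbon only, ortho to a large group, the 1-benzyl-1H-tetrazol-5-yl group of 12 heavy atoms can give way to a methyl of 1 heavy atom with little consequence in this assay (a 1.4-fold higher number from compound 3 to compound 4 (0.15 log units; within the scatter)), and the comparison with the 2-benzyl-2H-tetrazol-5-yl group gives the same picture (no change at the digits printed from compound 1 to compound 4 (within the scatter)). Neither benzyl-bearing tetrazole is therefore required for a number in this range, and the much smaller methyl serves as well as either. The (tert-butyl)sulfamoyl group now stands apart, since methyl in its place also gives a clear drop (a 4.0-fold lower number from compound 2 to compound 4 (0.60 log units; beyond the scatter)), so the higher number of compound 2 cannot be read as a simple result of having a smaller group than the tetrazoles.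

Going by these compounds, it remains open whether other small groups in this place, such as an amine, a carboxylic acid or a plain hydrogen, would give numbers like that of compound 4, or whether a longer chain would do the same. Nothing available here explains why groups so different in size give such similar numbers.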